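This account rests on a few compounds, and the source may have more. Where it says the series, first, only, none or still open, it means among the compounds named here.

Measured in a functional assay on K562 cells (Homo sapiens) for cytotoxicity, read by MTT assay, with a stated time of 48 h; on this read-out lower numbers stand for stronger inhibition and higher numbers for weaker inhibition:
Compound 1 `CCOC(=O)[C@]1(C(=O)Nc2ccccc2)C[C@@H]1c1cc(OC)c(OC)c(OC)c1`: > 100000 nM, a limit of the assay
Compound 2 `CCOC(=O)[C@]1(C(=O)NCc2ccc(C)cc2)C[C@H]1c1cc(OC)c(OC)c(OC)c1`: > 100000 nM, a limit of the assay
Compound 3 `CCOC(=O)[C@]1(C(=O)Nc2ccccc2Cl)C[C@@H]1c1cc(OC)c(OC)c(OC)c1`: 19500 nM

Compound 3 is the only one of the three with an actual number. The other two results share one ceiling, (the limit of > 100000 nM in this assay, at which 2 of the 3 values shown sit).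

The next compound to be tested in this assay is compound 4 `CCOC(=O)[C@]1(C(=O)NCc2ccc(C)cc2)C[C@@H]1c1cc(OC)c(OC)c(OC)c1`. Compared with compound 3, it carries 4-methylbenzyl in place of 2-chlorophenyl on an amide-type nitrogen.

Within the data shown here, one measured step bears on this change. With chloro in place of hydrogen on an aromatic carbon, the series showed an at least 5.1-fold lower number from compound 1 to compound 3 (0.70 log units; beyond the scatter), a step beyond the scatter. Compound 4 gives up that chlorine-bearing group, so this gain may well be lost. Compound 2 also carries 4-methylbenzyl, and compound 2 gave only the limit > 100000 nM.

A step of at least similar size is therefore expected in this assay, towards a higher number and weaker inhibition, and a result reported only as a limit is more likely than not. The expected change is a 4.1-fold higher number from compound 3 to compound 4 (0.61 log units; beyond the scatter). Compound 4 is estimated at 80000 nM, with an expected range from 25000 nM to 200000 nM.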

Compound 4, half-maximal inhibitory concentration: 20400 nM
For compound 4 the middle estimate is 3.9-fold (0.59 log units) above the measured one, outside the stated range (below it).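

In this assay, the series shows a 1.0-fold higher number from compound 3 to compound 4 (0.02 log units; within the scatter), so on this configuration 4-methylbenzyl on the amide-type nitrogen serves as well as 2-chlorophenyl, and a measurable value does not depend on the chlorine-bearing group. The series also shows an at least 4.9-fold lower number from compound 2 to compound 4 (0.69 log units; beyond the scatter), and this step can be tied to a single stereocentre at a saturated ring carbon, drawn S in compound 2 and R in compound 4: the fact that compounds 2 and 4 differ only in the configuration as drawn With the same configuration as compound 4, the phenyl compound gives an at least 4.9-fold lower number from compound 1 to compound 4 (0.69 log units; beyond the scatter), and this step and the one from compound 2 both start from a limit rather than a number, so their true size remains unknown: the limit of > 100000 nM in this assay, at which 2 of the 4 values shown sit.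

The compounds shown leave open whether the stereocentre carries the same weight when 2-chlorophenyl sits on the amide-type nitrogen, since only 4-methylbenzyl is seen with both drawings. They also leave open how this position would respond to a different kind of group, such as a longer chain ending in an amine or a carboxylic acid.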